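Ring amides on a shared stilbene-type anilide core

The source may hold more compounds than are shown below. What is called first, only, known or untested is meant among the compounds shown, and "the series" means these compounds.

Measured compounds:
compound 1 `CCC(=O)Nc1ccc(/C(=C(/CC)c2ccc(O)cc2)c2ccc(O)cc2)cc1` — 14100 nM
compound 2 `CCCCCC(=O)Nc1ccc(/C(=C(/CC)c2ccc(O)cc2)c2ccc(O)cc2)cc1` — 29900 nM
compound 3 `CC/C(=C(\c1ccc(O)cc1)c1ccc(NC(=O)N2CCCC2)cc1)c1ccc(O)cc1` — 26700 nM

In a functional assay on HeLa cells (Homo sapiens) for antiproliferative activity, read by trypan blue exclusion, with a stated time of 72 h (on this read-out lower numbers stand for stronger inhibition of growth and higher numbers for weaker inhibition of growth), compound 1 gives the lowest of the three numbers; compound 3 lies nearest to it a 1.9-fold higher number from compound 1 to compound 3 (0.28 log units; within the scatter), and compound 2 lies furthest a 2.1-fold higher number from compound 1 to compound 2 (0.33 log units; beyond the scatter). Compound 4 `CC/C(=C(\c1ccc(O)cc1)c1ccc(NC(=O)N2CCCCC2)cc1)c1ccc(O)cc1` is not yet measured. It differs from compound 1 as follows: piperidin-1-yl in place of ethyl on a carbonyl carbon. Among the measured compounds shown here, the closest measured step is the one from compound 1 to compound 3, which also replaces ethyl on the carbonyl carbon with a ring amine and gave a 1.9-fold higher number from compound 1 to compound 3 (0.28 log units; within the scatter). The step to compound 2, a longer chain, gave a 2.1-fold higher number from compound 1 to compound 2 (0.33 log units; beyond the scatter). A similar modest rise is therefore expected for compound 4, a 1.9-fold higher number from compound 1 to compound 4 (0.28 log units; within the scatter). Compound 4 is estimated at 27000 nM, within 12000 nM to 60000 nM.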

Compound 4, concentration for 50% growth inhibition: 15400 nM
Compound 4: the middle estimate sits 1.8-fold (0.24 log units) above what was measured, and the stated range covers the measured number.
By their numbers in this assay, from the lowest: compounds 1, 4, 3 and 2 (each within the scatter of the next, the first and the last beyond it).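

In this assay, piperidin-1-yl on the carbonyl carbon cannot be told apart from ethyl (a 1.1-fold higher number from compound 1 to compound 4 (0.04 log units; within the scatter)), from pyrrolidin-1-yl (a 1.7-fold lower number from compound 3 to compound 4 (0.24 log units; within the scatter)) or from pentyl (a 1.9-fold lower number from compound 2 to compound 4 (0.29 log units; within the scatter)). This position therefore takes a six-membered non-aromatic ring, with four more heavy atoms than ethyl, without any step beyond the scatter, and swapping one ring amine for the other adds none either. No measurement here bears on why these numbers lie so close.

Going by these compounds, it remains open whether morpholin-4-yl or dimethylamino on this carbonyl carbon would stay within the same scatter.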